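A few compounds are considered here, and "the series" means these few. Any claim that something is new, unique, unknown or untested is made for them only; others in the source may bear on it.

Measured compounds:
- compound 1, `C=CCNc1nc(N)c(C(=O)N=C(N)N)nc1Cl`: 16%
- compound 2, `NC(N)=NC(=O)c1nc(Cl)c(N2CCCC2)nc1N`: 12%
- compound 3, `NC(N)=NC(=O)c1nc(Cl)c(Nc2ccccc2)nc1N`: 44%

In an assay for inhibition of acid-sensing ion channel 3 (Homo sapiens), read by patch clamp, tested at 1 uM (a lower number here means less inhibition, a higher number more inhibition at the concentration tested (going by the name of the read-out)), compound 3 stands highest of the three. The step of a number 28 percentage points higher from compound 1 to compound 3 (beyond the scatter) came with phenyl in place of allyl on a nitrogen on an aromatic ring, and the step of a number 32 percentage points higher from compound 2 to compound 3 (beyond the scatter) came with anilino in place of pyrrolidin-1-yl on an aromatic carbon, while the step of a number 4 percentage points lower from compound 1 to compound 2 (within the scatter) made no real difference.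

Compound 4, `NC(N)=NC(=O)c1nc(Cl)c(Sc2ccccc2)nc1N`, differs from compound 3 in one place: phenylsulfanyl in place of anilino on an aromatic carbon. The change keeps the phenyl ring that both larger steps brought in, but the ring is now carried by sulfur rather than nitrogen, and the hydrogen-bond donor counted for anilino is gone. Going by the values given here, no measured step exchanges these two atoms, so the earlier steps are only a partial guide: they show that a phenyl group at this position went with higher inhibition, but not whether the nitrogen that carries it is needed. Compound 4 is therefore expected to keep part of the gain, with a downward step a number 14 percentage points lower from compound 3 to compound 4 (beyond the scatter) expected as the donor is lost. The estimate for compound 4 is 30%, within a range from 10% to 55%.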

Compound 4, a percentage reported as inhibition, at one concentration (the size of the read-out at that concentration, not a potency): 11%
Estimate against measurement, compound 4: 19 percentage points above; the measured number falls inside the stated range.
By their numbers in this assay, from the lowest: compounds 4, 2 and 1 (each within the scatter of the next); then compound 3.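

In this assay the phenyl ring alone does not carry the gain at this position: with the ring kept and only the linking atom exchanged, sulfur for nitrogen, a number 33 percentage points lower from compound 3 to compound 4 (beyond the scatter) takes away what anilino had added. Compound 4 also cannot be told apart from the two compounds without a phenyl ring, as a number 1 percentage points lower from compound 2 to compound 4 (within the scatter) and a number 5 percentage points lower from compound 1 to compound 4 (within the scatter) show, so among these four compounds the higher inhibition appears only with anilino. The counts show that anilino has a hydrogen-bond donor and phenylsulfanyl has none, but no measurement at hand connects that difference to the result.

A methyl(phenyl)amino group, which keeps the nitrogen and the phenyl ring but replaces the hydrogen on that nitrogen with methyl, would test whether that hydrogen matters, and phenoxy would show how a third linking atom compares. From the compounds shown here alone, it also remains open whether a methoxy group or a fluorine on the phenyl ring of anilino would raise or lower the inhibition.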